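A few compounds are considered here, and "the series" means these few. Any claim that something is new, unique, unknown or untested is made for them only; others in the source may bear on it.

Of the compounds shown here, three have so far been tested in an assay on isolated protein (Cavia porcellus) with Sigma non-opioid intracellular receptor 1 (Homo sapiens) as the target, read by radioligand binding; on this read-out higher numbers stand for weaker inhibition and lower numbers for stronger inhibition. Compound 1 `CN(C)CCCCCCCCCOc1ccc2oc(-c3ccccc3)cc(=O)c2c1` gives 334 nM in this assay, the highest of the three numbers; its gaps to the other two lie beyond the usual scatter, and it is the weakest binder among them. Compound 2 `O=c1cc(C2CCCC2)oc2ccc(OCCCCCCN3CCCCC3)cc12` gives 26 nM and compound 3 `O=c1cc(-c2ccccc2)oc2cc(OCCCCCCN3CCC(O)CC3)ccc12` gives 45 nM. Compound 4 `NCCCCCCOc1ccc2oc(-c3ccccc3)cc(=O)c2c1` has not yet been measured; compared with compound 1, the change is amino in place of 3-(dimethylamino)propyl on a saturated chain carbon, six bonds along the chain from an oxygen on an aromatic ring. Among the compounds with values here, no measured pair shows this change, and the direction rests on the structural difference alone. A modest weakening is expected, with a 2.1-fold higher number from compound 1 to compound 4 (0.32 log units; beyond the scatter) expected to lie beyond the scatter. Compound 4 is therefore estimated at 700 nM in this assay, with a range from 150 nM to 3000 nM.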

Compound 4, half-maximal inhibitory concentration: 2100 nM
Compound 4: the middle estimate sits 3.0-fold (0.48 log units) below what was measured; the range from low to high includes it.
By their numbers in this assay, from the lowest: compounds 2 and 3 (each within the scatter of the next); then compound 1; then compound 4.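

In this assay, amino in place of 3-(dimethylamino)propyl on this saturated chain carbon gives a 6.3-fold higher number from compound 1 to compound 4 (0.80 log units; beyond the scatter), the first measured sign that binding weakens when this end of the chain is cut back. The change removes chain carbons and the methyl groups on the nitrogen together, so this single step cannot separate their contributions. Nothing available explains the loss. Still open, going by these compounds, is how a dimethylamino group would compare with the amino group on the shorter chain. On these data alone, an amino group on the longer chain of compound 1 remains equally open.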